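This account rests on a few compounds, and the source may have more. Where it says the series, first, only, none or still open, it means among the compounds named here.

In an ADME assay on Vero cells (Chlorocebus sabaeus) for cytotoxicity, with a stated time of 72 h (on this read-out lower numbers stand for stronger inhibition and higher numbers for weaker inhibition), compound 1 `CCOC(=O)c1cc(/C=C/c2cccc(C(F)(F)F)c2)on1` gives > 128000 nM, which is a limit. Compound 2 `CCOC(=O)c1cc(/C=C/c2cccc([N+](=O)[O-])c2)on1` also gives only a limit, > 128000 nM. Compound 3 `CCOC(=O)c1cc(/C=C/c2cccc(-c3ccccn3)c2)on1` carries pyridin-2-yl in place of nitro on an aromatic carbon. For the measured compounds named here, the one measured step bearing on this change is a step that the two limits leave unreadable from compound 1 to compound 2, and the evidence on it is the limit of > 128000 nM in this assay, at which 2 of the 2 values shown sit. That step offers no size to carry over, so only a small move toward stronger inhibition in this assay is expected, the estimated at least 1.2-fold lower number from compound 2 to compound 3 (0.10 log units; that floor lies within the scatter). For compound 3 the estimated value is 100000 nM, with an expected range of 40000 nM to 128000 nM.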

Compound 3, half-maximal inhibitory concentration: 113000 nM
Estimate against measurement, compound 3: 1.1-fold (0.05 log units) below; the measured number falls inside the stated range.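

With pyridin-2-yl on this aromatic carbon, the series gains its first readable number in this assay, where the two earlier compounds offered only limits. Pyridin-2-yl in place of nitro gives an at least 1.1-fold lower number from compound 2 to compound 3 (0.05 log units; that floor lies within the scatter), and pyridin-2-yl in place of trifluoromethyl gives an at least 1.1-fold lower number from compound 1 to compound 3 (0.05 log units; that floor lies within the scatter). A six-membered aromatic ring is thus tolerated at this place, with only floors on the steps and none beyond the scatter: the limit of > 128000 nM in this assay, at which 2 of the 3 values shown sit.

On these data alone, the true size of both steps remains open. So does whether phenyl, an amine or a carboxylic acid on this aromatic carbon would give a clearly lower number.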